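Methylation of a phenol across two related cores

The source may report more compounds than this note shows. Statements on the series, on what has been measured and on what is new or still open speak of the compounds shown alone.

Compound 1 `O=C(Nc1cccc(-n2cc(-c3ccncc3)c(-c3cc(O)cc(Cl)c3)n2)c1)Nc1ccc(Cl)c(C(F)(F)F)c1` and compound 2 `COc1cc(Cl)cc(-c2nn(-c3cccc(NC(=O)Nc4ccc(Cl)c(C(F)(F)F)c4)c3)cc2-c2ccncc2)c1` share one core and differ in a single place, (methyl in place of hydrogen on an oxygen on an aromatic ring). In a functional assay on NCI/ADR-RES cells (Homo sapiens) for inhibition, read by sulforhodamine B assay, with a stated time of 48 h, tested at 10 uM (a higher number here means a weaker effect of the compound at the concentration tested, a lower number a stronger effect), compound 1 gives 41.5%, while compound 2 gives 6.07%; the change made a number 35.4 percentage points lower from compound 1 to compound 2 (beyond the scatter). Compound 3 `O=C(Nc1cccc(-n2cc(-c3ccncc3)c(-c3cc(O)cc(Cl)c3)n2)c1)c1cc(C(F)(F)F)cc(C(F)(F)F)c1` carries a different core, and the difference between the two cores is not broken down here. In this assay compound 3 gives 46.9%, a reading that lies within the scatter of compound 1 and far from compound 2. Compound 4 `COc1cc(Cl)cc(-c2nn(-c3cccc(NC(=O)c4cc(C(F)(F)F)cc(C(F)(F)F)c4)c3)cc2-c2ccncc2)c1` has not yet been measured; it differs from compound 3 by methyl in place of hydrogen on an oxygen on an aromatic ring, the same change that separates compound 1 from compound 2, made at the same place. For the measured compounds named here, only one measurement of this change exists. Because that change gave a number 35.4 percentage points lower from compound 1 to compound 2 (beyond the scatter), a step of similar size is expected here, a number 33.9 percentage points lower from compound 3 to compound 4 (beyond the scatter). For compound 4 the estimated value in this assay is 13%, with an expected range from 2% to 35%.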

Compound 4, a percentage reported as activity, at one concentration (the size of the read-out at that concentration, not a potency): 67.8%
For compound 4 the middle estimate is 54.8 percentage points below the measured one; the measured number lies above the stated range.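

In this assay the change from hydroxy to methoxy gave a number 20.9 percentage points higher from compound 3 to compound 4 (beyond the scatter) and thus a weaker effect at the concentration tested, whereas the same change on the core of compound 1 gave a stronger one, so neither its direction nor its size carried over from one core to the other: the same change on two cores in this assay, a number 35.4 percentage points lower (beyond the scatter) from compound 1 to compound 2 and a number 20.9 percentage points higher (beyond the scatter) from compound 3 to compound 4, 56.3 percentage points apart, beyond the scatter of two such steps. The change therefore cannot be transferred between these two cores on the strength of one pair, and its outcome here depends on the core that carries it. The two pairs do not show why the steps part, which feature of the cores is responsible, or how the change would behave on any further core.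

On these data alone, it remains open whether a longer chain on that oxygen, or an amine in place of the hydroxy, would also split between the two cores. Also open, as far as these compounds go, is which part of the difference between the cores goes with the reversal.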